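Side-chain swaps on a shared core: outlook for compound 4

This account rests on a few compounds, and the source may have more. Where it says the series, first, only, none or still open, it means among the compounds named here.

The series rests on the core of compound 1 `COc1nonc1/C(=N/O)Nc1ccc(F)c(Br)c1`, which in an assay for inhibition of Indoleamine 2,3-dioxygenase 1 (Homo sapiens), read by fluorescence, with a stated time of 1 h (on this read-out lower numbers stand for stronger inhibition and higher numbers for weaker inhibition), gives 230 nM. Compound 2 `NS(=O)(=O)CC(=O)NCCSc1nonc1/C(=N/O)Nc1ccc(F)c(Br)c1` gives 71 nM, and compound 3 `NS(=O)(=O)NCCOc1nonc1/C(=N/O)Nc1ccc(F)c(Br)c1` gives 150 nM; compound 3 thus stands second highest of the three numbers, close to compound 1 and somewhat apart from compound 2. Within the data shown here, the only single-point step in hand, a 1.5-fold lower number from compound 1 to compound 3 (0.19 log units; within the scatter), is small. Compound 4 `CS(=O)(=O)NCCSc1nonc1/C(=N/O)Nc1ccc(F)c(Br)c1` differs from compound 3 by a group of 8 heavy atoms (3 carbon, 1 nitrogen, 2 oxygen, 2 sulfur; no ring) in place of a group of 8 heavy atoms (2 carbon, 2 nitrogen, 3 oxygen, 1 sulfur; no ring), on an aromatic carbon. Among the measured compounds shown here, no measured step covers this exchange; the values of compound 2 and compound 3 show only that two different side chains on the same core lie beyond the scatter of each other. A modest shift is therefore expected in this assay, a 1.5-fold lower number from compound 3 to compound 4 (0.18 log units; within the scatter). Compound 4 is estimated at 100 nM, with a range of 40 nM to 250 nM.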

Compound 4, half-maximal inhibitory concentration: 270 nM
Estimate against measurement, compound 4: 2.7-fold (0.43 log units) below; measured number above the stated range.
By their numbers in this assay, from the lowest: compound 2; then compounds 3, 1 and 4 (each within the scatter of the next).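

At this aromatic carbon, the two exchanges read as a 1.8-fold higher number from compound 3 to compound 4 (0.26 log units; within the scatter) and a 1.2-fold higher number from compound 1 to compound 4 (0.07 log units; within the scatter), so this side chain is not separated from the small group on the core of compound 1. The one step beyond the scatter lies on the amine nitrogen, where methylsulfonyl in place of (sulfamoylmethyl)carbonyl gives a 3.8-fold higher number from compound 2 to compound 4 (0.58 log units; beyond the scatter), so among these compounds the group on that nitrogen marks the gap. No measurement at hand speaks to the reason for these numbers. Among these compounds, also open is how an amine or a carboxylic acid at the chain end, or a longer chain, would read, and no pair here isolates the oxygen of the chain from its sulfur.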